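This account rests on a few compounds, and the source may have more. Where it says the series, first, only, none or still open, it means among the compounds named here.

Compound 1 `O=C(O)c1ccccc1-c1ccc(CCc2ncc(CC3CCCC3)[nH]2)cc1` gives 133 nM in an in vitro functional assay on cells for agonist activity at Bombesin receptor subtype-3 (Homo sapiens), read by luminescence and calcium flux; on this read-out lower numbers stand for an effect already at smaller amounts and higher numbers for an effect only at larger amounts of compound; compound 2 `COc1ccc(Cc2cnc(CCc3ccc(-c4ccccc4C(=O)O)cc3)[nH]2)cc1` gives 5360 nM; compound 3 `N#Cc1ccccc1Cc1cnc(CCc2ccc(-c3ccccc3C(=O)O)cc2)[nH]1` gives 5480 nM.

Compound 3 shows the highest of the three numbers, though its gap to compound 2 is within the scatter (a 1.0-fold higher number from compound 2 to compound 3 (0.01 log units; within the scatter)), while the step from the saturated ring of compound 1 is large (a 41-fold higher number from compound 1 to compound 3 (1.61 log units; beyond the scatter)). Compound 4 `O=C(O)c1ccccc1-c1ccc(CCc2ncc(CC3CCCCCC3)[nH]2)cc1` differs from compound 3 by cycloheptyl in place of 2-cyanophenyl on a saturated chain carbon bound to an aromatic carbon. For the measured compounds named here, the one step that bears on this is the reverse of a 41-fold higher number from compound 1 to compound 3 (1.61 log units; beyond the scatter): putting an aromatic ring in place of a saturated one raised the number greatly. Returning to a saturated ring, now one ring size larger, is therefore expected to give a large decrease, a 25-fold lower number from compound 3 to compound 4 (1.40 log units; beyond the scatter), with no measured step covering cyclopentyl against cycloheptyl. Compound 4 is estimated at 220 nM, between 60 nM and 800 nM.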

Compound 4, half-maximal effective concentration: 88 nM
For compound 4 the middle estimate is 2.5-fold (0.40 log units) above the measured one; the range from low to high includes it.
By their numbers in this assay, from the lowest: compounds 4 and 1 (each within the scatter of the next); then compounds 2 and 3 (each within the scatter of the next).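

Cycloheptyl on this saturated chain carbon performs like cyclopentyl (a 1.5-fold lower number from compound 1 to compound 4 (0.18 log units; within the scatter)), so this larger saturated ring is tolerated just as well. The same position separates both saturated rings from the two substituted aromatic rings, with large steps for cycloheptyl against each (a 62-fold lower number from compound 3 to compound 4 (1.79 log units; beyond the scatter)) and (a 61-fold lower number from compound 2 to compound 4 (1.78 log units; beyond the scatter)). No measurement shown here explains this separation.

On these data alone, whether unsubstituted phenyl would behave like the substituted aromatic rings remains open. So does the effect of a smaller ring such as cyclopropyl, or of a ring carrying an amine, such as piperidinyl.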